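Trimming tert-butyl to methyl on a pendant aryl ring

A few compounds are considered here, and "the series" means these few. Any claim that something is new, unique, unknown or untested is made for them only; others in the source may bear on it.

Compound 1 `O=C1O/C(=C\Cn2cc(Cc3ccccc3)nn2)C(OCc2ccccc2)=C1OCc1ccccc1`: 83100 nM
Compound 2 `CC(C)(C)c1ccc(-c2cn(C/C=C3\OC(=O)C(OCc4ccccc4)=C3OCc3ccccc3)nn2)cc1`: > 100000 nM

Going by these compounds, in a functional assay on HCT-116 cells (Homo sapiens) for antiproliferative activity, read by MTT assay, with a stated time of 24 h (a higher number here means a weaker inhibitor, a lower number a stronger inhibitor), compound 2 gives only a limit, > 100000 nM, so its exact value is unknown (the limit of > 100000 nM in this assay, at which 1 of the 2 values shown sits). Compound 1 gives 83100 nM in this assay. Going by the values given here, the only measured step, an at least 1.2-fold higher number from compound 1 to compound 2 (0.08 log units; that floor lies within the scatter), lies within the scatter. Compound 3 `Cc1ccc(-c2cn(C/C=C3\OC(=O)C(OCc4ccccc4)=C3OCc3ccccc3)nn2)cc1` carries methyl in place of tert-butyl on an aromatic carbon. That measured step, being a floor, gives little guidance. Compound 3 is therefore expected to sit near compound 2, with a step of a number no higher from compound 2 to compound 3 (the limit leaves the size open). The estimate for compound 3 is 100000 nM, ranging from 40000 nM to 250000 nM.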

Compound 3, half-maximal inhibitory concentration: > 100000 nM
Compound 3: only a limit was reported (the forecaster's own chance of this, stated with the estimate: 55%); the middle value lies on the limit itself.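

Trimming tert-butyl to methyl gives no readable change in this assay because compound 2 and compound 3 both stand at a limit, and the step between them cannot be read: the limit of > 100000 nM in this assay, at which 2 of the 3 values shown sit. With 4-methylphenyl in place of benzyl, the result is only a floor, an at least 1.2-fold higher number from compound 1 to compound 3 (0.08 log units; that floor lies within the scatter), so this swap shows no change beyond the scatter. Methyl and tert-butyl therefore both leave compound 3 and compound 2 at that limit.

Going by these compounds, how far beyond the limit either compound lies remains open. So does whether an amine or a carboxylic acid on that ring would give a readable value.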